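Shortening the sulfonyl aryl substituent in a sulfonamide-amine series

This account rests on a few compounds, and the source may have more. Where it says the series, first, only, none or still open, it means among the compounds named here.

Of the compounds shown here, two have numbers so far. Compound 1 `CCCCc1ccc(S(=O)(=O)NCCCCCCNCc2ccc(Br)cc2)cc1` gives 5700 nM in a functional assay on MIA PaCa-2 cells (Homo sapiens) for inhibition, read by MTT assay, with a stated time of 72 h; on this read-out higher numbers stand for weaker inhibition of growth and lower numbers for stronger inhibition of growth. Compound 2 `COc1ccccc1CNCCCNS(=O)(=O)c1cc(C(F)(F)F)cc(C(F)(F)F)c1`, which carries a different linker and different aryl groups at both ends, gives 3100 nM in the same assay. Compound 1 stands at the upper end of these two numbers, but its gap to compound 2 lies within the usual scatter, so the two are not separated on this read-out. Within the data shown here, no single-point step between measured compounds is available, and compound 2 shares neither its linker nor its substituents with compound 1, so it offers no direct guide.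

Compound 3 `Cc1ccc(S(=O)(=O)NCCCCCCNCc2ccc(Br)cc2)cc1` is the next point. It differs from compound 1 by hydrogen in place of propyl on a saturated chain carbon bound to an aromatic carbon. The shared core, linker and bromine-bearing end are untouched. Among the measured compounds shown here, with no measured step to rest on, the expectation is a small shift toward a higher number, of a size that may not rise above the scatter: the step from compound 1 to compound 3 is estimated as a 1.6-fold higher number from compound 1 to compound 3 (0.20 log units; within the scatter). Compound 3 is accordingly expected to give about 9000 nM in this assay, within a range of 4000 nM to 25000 nM.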

Compound 3, concentration for 50% growth inhibition: 12300 nM
Compound 3: the middle estimate sits 1.4-fold (0.14 log units) below what was measured; the measured number falls inside the stated range.
By their numbers in this assay, from the lowest: compounds 2 and 1 (each within the scatter of the next); then compound 3.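

In this assay, among these compounds, the step of a 2.2-fold higher number from compound 1 to compound 3 (0.33 log units; beyond the scatter) is the first single-place comparison, and it comes from hydrogen in place of propyl on a saturated chain carbon bound to an aromatic carbon, which cut one bond further out reads butyl to methyl. It shows that this position is not silent: with the shared core, the linker and the bromine-bearing end unchanged, shortening the butyl to methyl moves the number beyond the scatter, though only modestly, and toward weaker inhibition of growth. Nothing measured here speaks to the origin of this shift.

A single step cannot show whether the number tracks chain length, and an ethyl group, a longer chain such as hexyl or a branched tert-butyl group in place of the butyl would be needed to define that relationship. Also open, on these data alone, are whether a chain ending in a hydroxyl group or a carboxylic acid would sit with compound 1 or with compound 3, and whether the same change gives a step of similar size on a different linker.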